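Methyl for methoxy on the carbonyl of compound 2

This account rests on a few compounds, and the source may have more. Where it says the series, first, only, none or still open, it means among the compounds named here.

Measured so far:
compound 1, `COC(=O)c1cc2cc(NCc3cc(NC(=O)c4cncc(C(F)(F)F)c4)ccc3C)cnc2[nH]1`: 963 nM
compound 2, `COC(=O)c1cc2cc(CCc3cc(NC(=O)c4ccc(CN5CCC(N(C)C)C5)c(C(F)(F)F)c4)ccc3C)cnc2[nH]1`: > 1000 nM

Of the compounds shown here, two have been measured in a functional assay on HepG2 cells (Homo sapiens) for antiproliferative activity, read by MTT assay, with a stated time of 72 h; a lower number here means that less compound is needed, a higher number that more compound is needed for the effect. Compound 1 gives 963 nM in this assay. Compound 2 returns only a limit of the assay, > 1000 nM, and so stands at the limit of > 1000 nM in this assay, at which 1 of the 2 values shown sits. Among the measured compounds shown here, no pair of measured compounds differs in a single place, so no measured step is available to lean on.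

Compound 3, `CC(=O)c1cc2cc(CCc3cc(NC(=O)c4ccc(CN5CCC(N(C)C)C5)c(C(F)(F)F)c4)ccc3C)cnc2[nH]1`, differs from compound 2 by methyl in place of methoxy on a carbonyl carbon. Compound 2 itself is known only as a limit, so the starting point of this step is not a number. The expected step is a step that the limit leaves unreadable from compound 2 to compound 3, which amounts to nothing beyond the scatter. Compound 3 is therefore estimated at 3000 nM, with a range from 800 nM to 15000 nM, and a fair chance that this assay again reports only a limit.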

Compound 3, half-maximal effective concentration: 248 nM
For compound 3 the middle estimate is 12-fold (1.08 log units) above the measured one; the whole stated range lies above it.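

In this assay, the carbonyl carbon whose other neighbour is an aromatic carbon proves sensitive to the group it carries: the change from methoxycarbonyl to acetyl brings an at least 4.0-fold lower number from compound 2 to compound 3 (0.60 log units; beyond the scatter). Among the compounds shown here, this is the first step between compounds that differ in one place, and it shows that swapping methoxy for methyl on this carbonyl alone moves the number beyond the scatter. The step has no fixed size, only a bound, because compound 2 is known only as a limit: the limit of > 1000 nM in this assay, at which 1 of the 3 values shown sits.

The compounds shown leave open how a carboxylic acid, a primary amide or a ketone with a longer chain would read at this carbonyl carbon. They also leave open whether the same change would carry over to compound 1, which differs from compound 2 in more than one place.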